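This account rests on a few compounds, and the source may have more. Where it says the series, first, only, none or still open, it means among the compounds named here.

Measured compounds, in a functional assay on CHO cells for inhibition of Orexin/Hypocretin receptor type 1 (Homo sapiens), read by FLIPR and calcium flux; on this read-out higher numbers stand for weaker inhibition and lower numbers for stronger inhibition:
- compound 1 `CCN(CC)C(=O)CN(c1ccc(C)cc1)S(=O)(=O)c1ccc(OC)c(OC)c1`: > 10000 nM, a limit of the assay, not a number.
- compound 2 `CCN(C(=O)CN(c1cc(N(C)C)ccc1Cl)S(=O)(=O)c1ccc(OC)c(OC)c1)c1ccn(C)n1`: 12 nM.
- compound 3 `CCN(CC)C(=O)CN(c1ccc(C)cc1)S(=O)(=O)c1ccc(C(C)(C)C)cc1`: > 10000 nM, likewise a limit.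

Compound 1 thus stands at the limit, as the evidence states: the limit of > 10000 nM in this assay, at which 2 of the 3 values shown sit. Compound 2 alone gives a number, and it is a low one.

Compound 4 `CCN(CC)C(=O)CN(c1cc(N(C)C)ccc1OC)S(=O)(=O)c1ccc(OC)c(OC)c1` differs from compound 1 by 5-(dimethylamino)-2-methoxyphenyl in place of 4-methylphenyl on a sulfonamide nitrogen, in words: 5-(dimethylamino)-2-methoxyphenyl in place of 4-methylphenyl on a sulfonamide nitrogen. Going by the values given here, no measured pair isolates this change. The dimethylamino-bearing aryl of compound 2 is the only feature shared with a compound that gives a number, so a step well beyond the scatter toward stronger inhibition is expected from compound 1 to compound 4, estimated at an at least 33-fold lower number from compound 1 to compound 4 (1.52 log units; beyond the scatter). Compound 4 is expected at 300 nM, between 30 nM and 3000 nM.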

Compound 4, half-maximal inhibitory concentration: > 10000 nM
Compound 4: no number, only a limit; the forecaster's own chance of this, stated with the estimate: 15%; middle value at least 33-fold (1.52 log units) from the limit.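

Going by these compounds alone, compound 1 and compound 4 both stand at a limit in this assay, and no step between them can be read. The compounds shown leave open which of the differences between compound 4 and compound 2 goes with the number of compound 2.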